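Changing the aryl group on the amide of compound 2

The source may hold more compounds than are shown below. What is called first, only, known or untested is meant among the compounds shown, and "the series" means these compounds.

- Compound 1 `COc1ccc(NC(=O)CN2CCN(c3nnc(Cc4ccccc4)c4ccccc34)CC2)cc1OC`: 32200 nM
- Compound 2 `O=C(CN1CCN(c2nnc(Cc3ccccc3)c3ccccc23)CC1)Nc1ccc(F)c(Cl)c1`: 7360 nM

Within the data shown here, in a functional assay on MDA-MB-231 cells (Homo sapiens) for cytotoxicity, read by MTT assay, with a stated time of 72 h (a lower number here means a stronger inhibitor, a higher number a weaker inhibitor), compound 2 holds the lower of the two numbers measured so far, at 7360 nM. Compound 3 `Cc1ccc(NC(=O)CN2CCN(c3nnc(Cc4ccccc4)c4ccccc34)CC2)c(C)c1` has the same core and differs from it at one place: 2,4-dimethylphenyl in place of 3-chloro-4-fluorophenyl on an amide-type nitrogen. Among the measured compounds shown here, only one measured step bears on this change, and it sits on the same amide-type nitrogen: a 4.4-fold lower number from compound 1 to compound 2 (0.64 log units; beyond the scatter). This modest step shows that the number in this assay can move with the group at this place. For the measured compounds named here, it involves different groups, however, and no measured compound carries 2,4-dimethylphenyl, so the direction remains uncertain. With compound 2 at the lower end of the measured span, a modest move towards a higher number seems most likely. The estimated change is a 2.2-fold higher number from compound 2 to compound 3 (0.34 log units; beyond the scatter). For compound 3 the expected value is 16000 nM. The estimated range for compound 3 runs from 6000 nM to 40000 nM.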

Compound 3, half-maximal inhibitory concentration: 181000 nM
Compound 3: middle estimate off by 11-fold (1.05 log units), on the low side; the measured number lies above the stated range.
By their numbers in this assay, from the lowest: compound 2; then compound 1; then compound 3.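

In this assay, the aryl group on the amide-type nitrogen can move the number much further than the first pair suggested, with a 25-fold higher number from compound 2 to compound 3 (1.39 log units; beyond the scatter) when 2,4-dimethylphenyl replaces 3-chloro-4-fluorophenyl. Both groups are printed with the same count of heavy atoms and one six-membered aromatic ring of carbon only, so a large shift occurs here without any change in those counts. The replacement of 3,4-dimethoxyphenyl also goes upward, with a 5.6-fold higher number from compound 1 to compound 3 (0.75 log units; beyond the scatter), which places 2,4-dimethylphenyl highest of the three aryl groups.

No supporting evidence explains the size of this rise. As far as these compounds go, it also remains open whether either methyl alone accompanies the rise, and where a plain phenyl, a 4-methylphenyl or a pyridine ring would fall.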